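Urea aryl exchange on the shared core

The compounds below may be only part of what the source reports. "The series", "measured", "known", "first", "only" and "open" are said of these compounds alone.

Three measured compounds share one core and one read-out, a functional assay on HepG2 cells (Homo sapiens) for inhibition, with a stated time of 72 h; a higher number here means a weaker inhibitor, a lower number a stronger inhibitor. Compound 1 `Cc1cc(Cl)ccc1NC(=O)Nc1nc(Sc2c[nH]c3ccccc23)cc(N2CCN(Cc3ccccc3)CC2)n1` gives 11700 nM in this assay, the lowest of the three numbers, yet compound 3 `O=C(Nc1ccccc1)Nc1nc(Nc2ccc(Cl)cc2)cc(Sc2c[nH]c3ccccc23)n1` with 12600 nM and compound 2 `O=C(Nc1ccc(Cl)cc1)Nc1nc(Sc2c[nH]c3ccccc23)cc(N2CCCCC2)n1` with 14800 nM both lie within the scatter of it, so no order among them is drawn. Compound 4 `COc1ccc(NC(=O)Nc2nc(Sc3c[nH]c4ccccc34)cc(N3CCN(Cc4ccccc4)CC3)n2)cc1` is not yet measured. It differs from compound 1 by 4-methoxyphenyl in place of 4-chloro-2-methylphenyl on an amide-type nitrogen. Going by the values given here, no step between measured compounds touches this position, so the data give no pointer for it. For compound 4 the step in this assay is expected to be a 1.1-fold higher number from compound 1 to compound 4 (0.05 log units; within the scatter), none beyond the scatter. On that basis compound 4 is estimated at 13000 nM, with a range from 5000 nM to 35000 nM.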

Compound 4, half-maximal inhibitory concentration: 21400 nM
For compound 4 the middle estimate is 1.6-fold (0.22 log units) below the measured one; the range from low to high includes it.
By their numbers in this assay, from the lowest: compounds 1, 3, 2 and 4 (each within the scatter of the next).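

In this assay, going by these compounds alone, the exchange of 4-chloro-2-methylphenyl for 4-methoxyphenyl on the amide-type nitrogen gives a 1.8-fold higher number from compound 1 to compound 4 (0.26 log units; within the scatter) as the first step that can be read at this position. This one exchange therefore does not separate the two compounds. No measurement available here bears on the result.

Still open, on these data alone, is whether a cyclohexyl group or a carboxylic acid on the phenyl at this nitrogen would move the number beyond the scatter. One step also says little about how this position behaves with a different group on the rest of the shared core.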